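A 4-Chlorophenyl in Place of Isopropyl

This account rests on a few compounds, and the source may have more. Where it says the series, first, only, none or still open, it means among the compounds named here.

In a functional assay on MDA-MB-231 cells (Homo sapiens) for antiproliferative activity, read by MTT assay, with a stated time of 72 h (on this read-out higher numbers stand for weaker inhibition and lower numbers for stronger inhibition), compound 1 `CC(C)(C)NC(=O)CCc1cccc2c1B(O)OC2` gives > 100000 nM, which is a limit of the assay and not a number. Going by the values given here, compound 2 `O=C(CCc1cccc2c1B(O)OC2)Nc1ccc(I)cc1` gives 33000 nM, and compound 3 `CC(C)c1cccc(NC(=O)CCc2cccc3c2B(O)OC3)c1` gives 1600 nM, the lowest number so far. Compound 4 `O=C(CCc1cccc2c1B(O)OC2)Nc1cccc(-c2ccc(Cl)cc2)c1` carries 4-chlorophenyl in place of the isopropyl of compound 3 on an aromatic carbon, meta to a large group (4-chlorophenyl in place of isopropyl on an aromatic carbon). Among the compounds with values here, only one measured step bears on this change: 4-iodophenyl in place of tert-butyl on an amide-type nitrogen gave an at least 3.0-fold lower number from compound 1 to compound 2 (0.48 log units; beyond the scatter). The size of that step rests on (the limit of > 100000 nM in this assay, at which 1 of the 3 values shown sits). It also brought in an aromatic ring, but at another place in the molecule, so it is only a loose guide. A modest lowering is therefore expected, an estimated 2.3-fold lower number from compound 3 to compound 4 (0.36 log units; beyond the scatter). Compound 4 is estimated at 700 nM, with an expected range of 150 nM to 3500 nM.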

Compound 4, half-maximal inhibitory concentration: 260 nM
For compound 4 the middle estimate is 2.7-fold (0.43 log units) above the measured one; measured number inside the range.
By their numbers in this assay, from the lowest: compound 4; then compound 3; then compound 2. At a limit, above all of these: compound 1.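

In this assay, this aromatic carbon, meta to a large group, tolerates more than the isopropyl: 4-chlorophenyl in its place gives a 6.2-fold lower number from compound 3 to compound 4 (0.79 log units; beyond the scatter), so the number falls further when a second aromatic ring is added at this place. Going by these compounds alone, the only earlier step lay on the amide-type nitrogen, which makes this the first direct reading at this position, and it compares two true numbers, with no limit involved. Nothing measured in this series accounts for the size of the step.

On these data alone, it remains open whether the ring or its chlorine carries the change, and a plain phenyl or a 4-fluorophenyl at this place would separate the two. Also open, as far as these compounds go, is how a pyridine ring, or an amine on the added ring, would read here.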